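The source may hold more compounds than are shown below. What is called first, only, known or untested is meant among the compounds shown, and "the series" means these compounds.

Working notes on the series, read in an ADME assay on the whole organism for inhibition, with Echinochloa crus-galli var. formosensis as the target, with a stated time of 4 days; on this read-out higher numbers stand for weaker inhibition and lower numbers for stronger inhibition. Compound 1 `CCCN(CC)c1nc(Cl)nc(N[C@@H](C)c2ccccc2)n1` gives 282 nM, compound 2 `C[C@H](Nc1nc(Cl)nc(NC(C)(C)C)n1)c1ccccc1` gives 7410 nM, and compound 3 `CCNc1nc(Cl)nc(NC(C)c2ccccc2)n1` gives 9770 nM. Compound 2 and compound 3 lie within the scatter of each other, so compound 2 sits with compound 3 at the high-number end of this small set, well away from compound 1.

The next compound to be read is compound 4 `CCN(CC)c1nc(Cl)nc(N[C@@H](C)c2ccccc2)n1`. Going from compound 2 to compound 4 puts diethylamino in place of (tert-butyl)amino on an aromatic carbon.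

Among the compounds with values here, one measured step bears on this change: a 26-fold higher number from compound 1 to compound 2 (1.42 log units; beyond the scatter), where (tert-butyl)amino took the place of ethyl(propyl)amino. Read in reverse, that large step suggests the number should fall clearly when (tert-butyl)amino leaves compound 2 for diethylamino. Within the data shown here, this rests on a single step, and no compound carrying diethylamino has been read yet, so the expected size is set somewhat short of the measured one. The estimated step, large and towards stronger inhibition, is a 15-fold lower number from compound 2 to compound 4 (1.17 log units; beyond the scatter). For compound 4 the expected value is 500 nM, with an estimated range of 130 nM to 2000 nM.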

Compound 4, half-maximal inhibitory concentration: 257 nM
Beside the measured number, compound 4's estimate is 1.9-fold (0.29 log units) above it; low and high end bracket the measured number.
By their numbers in this assay, from the lowest: compounds 4 and 1 (each within the scatter of the next); then compounds 2 and 3 (each within the scatter of the next).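

In this assay, a 29-fold lower number from compound 2 to compound 4 (1.46 log units; beyond the scatter) shows that this position responds strongly even when the entering and leaving groups hold the same atoms, so heavy-atom count alone does not set the read-out here. a 1.1-fold lower number from compound 1 to compound 4 (0.04 log units; within the scatter) adds that ethyl(propyl)amino and diethylamino cannot be told apart in this assay, so the loss of one methyl from the chain on this nitrogen leaves the read-out within the scatter, and these two groups give the same picture against (tert-butyl)amino. Within the data shown here, no measurement on the compounds bears on why the exchange of (tert-butyl)amino for diethylamino moves the number so far.

The step from compound 2 to compound 4 changes two things together, since (tert-butyl)amino carries a hydrogen-bond donor and a branched chain while diethylamino has neither, and the compounds shown do not separate the two. Unbranched butylamino and tert-butyl(methyl)amino at this position would pull them apart, and dipropylamino would show whether the tolerance for chain length extends beyond ethyl(propyl)amino.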